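Methoxy in Place of Bromo: Compound 1 to Compound 4

The source may hold more compounds than are shown below. What is called first, only, known or untested is meant among the compounds shown, and "the series" means these compounds.

Compound 1 `O=C(/C=C/c1ccc(OCc2cn(Cc3ccccc3)nn2)cc1)c1ccc(Br)cc1` stands second highest of three numbers in a functional assay on MCF7 cells (Homo sapiens) for inhibition, read by MTT assay, with a stated time of 48 h, tested at 10 uM (a higher number here means more inhibition of growth at the concentration tested, a lower number less inhibition of growth), where compound 1 gives 34%. Its nearest neighbour is compound 2 `O=C(/C=C/c1ccc(OCc2cn(Cc3cccc(Br)c3)nn2)cc1)c1ccc(Br)cc1`, which in this assay gives 36%, so that a number 2 percentage points higher from compound 1 to compound 2 (within the scatter) lies within the scatter. Furthest away is compound 3 `O=C(/C=C/c1ccc(OCc2cn(Cc3ccc(Br)cc3)nn2)cc1)c1ccc(Br)cc1`, which in this assay gives 23%; the step of a number 11 percentage points lower from compound 1 to compound 3 (beyond the scatter) is beyond the scatter, as is a number 13 percentage points lower from compound 2 to compound 3 (beyond the scatter). All three measured steps concern the group on the saturated chain carbon bound to an aromatic nitrogen. Compound 4 `COc1ccc(C(=O)/C=C/c2ccc(OCc3cn(Cc4ccccc4)nn3)cc2)cc1` differs from compound 1 in another part of the molecule: methoxy in place of bromo on an aromatic carbon. Among the compounds with values here, none of the measured steps touches this six-membered aromatic ring of carbon only, so the data give no direction for the change. The expectation is therefore a step of no change at the digits printed from compound 1 to compound 4 (within the scatter), nothing beyond the scatter. For compound 4 the estimate in this assay is 34%, with a range from 15% to 55%.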

Compound 4, percent growth inhibition at one concentration: 70%
For compound 4 the middle estimate is 36 percentage points below the measured one, outside the stated range (above it).
By their numbers in this assay, from the lowest: compound 3; then compounds 1 and 2 (each within the scatter of the next); then compound 4.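

Within the data shown here, this position on the six-membered aromatic ring of carbon only is untouched by the earlier steps, and in this assay methoxy in place of bromo gives a number 36 percentage points higher from compound 1 to compound 4 (beyond the scatter), while the largest earlier step, on the group at the saturated chain carbon, is a number 13 percentage points lower from compound 2 to compound 3 (beyond the scatter). Among the compounds shown, this place, para to a large group, therefore gives the largest step, although that rests on a single pair. No evidence at hand bears on why the number rises with this exchange.

From the compounds shown here alone, whether the rise belongs to methoxy in particular, or would also appear with hydroxyl, an amine or a longer alkoxy chain at this place, stays open. Also open, going by these compounds, is whether methoxy would give a like step on the cores of compound 2 and compound 3.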